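The compounds below may be only part of what the source reports. "The series", "measured", "known", "first", "only" and "open" are said of these compounds alone.

Measured compounds in a functional assay on HeLa cells (Homo sapiens) for inhibition, read by MTT assay, with a stated time of 24 h; a higher number here means a weaker inhibitor, a lower number a stronger inhibitor:
- compound 2 `Cc1ccc(NC(=O)COc2nc3ccccc3nc2C)cc1`: 74600 nM
- compound 1 `COc1ccc(NC(=O)Cn2c(=O)c(/C=C\c3ccncc3)nc3ccccc32)cc1OC`: > 100000 nM

Among the compounds with values here, compound 2 holds the only numerical value. In this assay compound 2 gives 74600 nM, a weak inhibition, and there is no second number to set it against. For compound 1 this assay reports a limit and not a number, > 100000 nM, which is the situation described by the limit of > 100000 nM in this assay, at which 1 of the 2 values shown sits. Within the data shown here, with one number and one limit, no step between measured compounds can be given, and nothing is known about how a change on the anilide ring moves the read-out within this core.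

Compound 3 `Cc1nc2ccccc2nc1OCC(=O)Nc1ccc(Cl)cc1` is the next compound for this assay. It differs from compound 2 by chloro in place of methyl on an aromatic carbon. Among the measured compounds shown here, no measured step informs this exchange, so no move beyond the scatter is expected in either direction. Compound 3 is expected to give about 65000 nM, with a plausible span from 20000 nM to 200000 nM. The expected step of a 1.1-fold lower number from compound 2 to compound 3 (0.06 log units; within the scatter) is thus estimated to stay within the scatter, with a real chance that this assay again reports only a limit.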

Compound 3, half-maximal inhibitory concentration: > 100000 nM
Compound 3: no number, only a limit; the forecaster's own chance of this, stated with the estimate: 35%; at least 1.5-fold (0.18 log units) between middle value and limit.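

In this assay compound 3 gives > 100000 nM, which is a limit and not a number. Within the data shown here, the exchange of 4-methylphenyl for 4-chlorophenyl now has a first reading, an at least 1.3-fold higher number from compound 2 to compound 3 (0.12 log units; that floor lies within the scatter); this gives a floor and no size, and that floor does not separate the two compounds. Compound 2 remains the only compound in the series with a number, so any further change at this position can be read only against it: the limit of > 100000 nM in this assay, at which 2 of the 3 values shown sit.

As far as these compounds go, what an amine, a carboxylic acid or a fluoro group on this same aromatic carbon would do to the read-out stays open, and so does whether any group in that place would give a clearly lower number than compound 2. Also open, from the compounds shown here alone, are the true size of the step from methyl to chloro and whether the same exchange would have any readable effect on the core of compound 1.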